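The source may hold more compounds than are shown below. What is called first, only, known or untested is meant among the compounds shown, and "the series" means these compounds.

In a functional assay on CCRF-CEM cells (Homo sapiens) for cytotoxicity, with a stated time of 72 h (on this read-out higher numbers stand for an effect only at larger amounts of compound and lower numbers for an effect already at smaller amounts), compound 1 `CC(C)=CCC/C(C)=C/Cc1c(O)cc2c(c1O)C(=O)C[C@@H](c1cc(O)cc(O)c1)O2` gives 12300 nM and compound 2 `CC(C)=CCC/C(C)=C/Cc1c(O)cc2c(c1O)C(=O)C[C@@H](c1ccc(O)c(O)c1)O2` gives 3200 nM as the lower of the two numbers. Compound 3 `COc1cc([C@@H]2CC(=O)c3c(cc(O)c(C/C=C(\C)CCC=C(C)C)c3O)O2)cc(O)c1O` differs from compound 2 by methoxy in place of hydrogen on an aromatic carbon and so carries 3,4-dihydroxy-5-methoxyphenyl in place of 3,4-dihydroxyphenyl. Among the compounds with values here, only one measured step bears on this change: a 3.8-fold lower number from compound 1 to compound 2 (0.58 log units; beyond the scatter) when 3,4-dihydroxyphenyl replaces 3,5-dihydroxyphenyl. Within the data shown here, that step is modest and rearranges hydroxy groups, whereas compound 3 keeps both hydroxy groups of compound 2 and adds a methoxy, a change no measured pair shows. It therefore serves only as a rough guide to size. In this assay a smaller step is expected, with no change beyond the scatter and an estimated 1.4-fold higher number from compound 2 to compound 3 (0.15 log units; within the scatter) as a slight drift toward a higher number. For compound 3 the estimated value is 4500 nM with an expected range from 1800 nM to 12000 nM in repeated measurements.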

Compound 3, half-maximal effective concentration: < 10000 nM
Compound 3: only a limit was reported; the forecaster's own chance of this, stated with the estimate: 5%; the middle value does not contradict the limit.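

In this assay compound 3 is reported as < 10000 nM, which is a limit and not a number. The step from compound 2 to compound 3 cannot be read because of this limit: the limit of < 10000 nM in this assay, at which 1 of the 3 values shown sits. Against the 3,5-dihydroxyphenyl group of compound 1, the 3,4-dihydroxy-5-methoxyphenyl group gives an at least 1.2-fold lower number from compound 1 to compound 3 (0.08 log units; that floor lies within the scatter), a floor within the usual scatter, so methoxy in place of hydrogen on this aromatic carbon is shown neither to raise nor to lower the number.

Going by these compounds, the size and direction of the methoxy step stay open until compound 3 has a measured number. The compounds shown also leave open how an amine or a carboxylic acid on this same aromatic carbon would read out.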